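Swapping nitro for acetamido in compound 1

The source may hold more compounds than are shown below. What is called first, only, known or untested is meant among the compounds shown, and "the series" means these compounds.

In a functional assay with Rattus norvegicus as the target (on this read-out lower numbers stand for an effect already at smaller amounts and higher numbers for an effect only at larger amounts of compound), compound 1 `C[C@@H](/N=C(\S)NCc1ccc(C(C)(C)C)cc1)c1ccc([N+](=O)[O-])cc1` gives > 100000 nM as a limit, not a number. Compound 2 `C[C@H](/N=C(\S)NCc1ccc(C(C)(C)C)cc1)c1ccc([N+](=O)[O-])cc1` gives > 100000 nM as a limit too. Compound 3 `Cc1ccc(C(C)/N=C(\S)NCc2ccc(C(C)(C)C)cc2)cc1` gives > 100000 nM as a limit as well. Compound 4 `CC(=O)Nc1ccc([C@@H](C)/N=C(\S)NCc2ccc(C(C)(C)C)cc2)cc1` carries acetamido in place of nitro on an aromatic carbon and is still unmeasured. Going by the values given here, the only measured step is a step that the two limits leave unreadable from compound 1 to compound 2 and it concerns the fact that compounds 1 and 2 differ only in the configuration as drawn so it does not bear on this swap. Given the limit of > 100000 nM in this assay, at which 3 of the 3 values shown sit, nothing measured points to a step in either direction. For compound 4 the expected change is a number no higher from compound 1 to compound 4 (the limit leaves the size open) in this assay and no step beyond the scatter is expected. For compound 4 the estimated value is 100000 nM within a range from 15000 nM to 300000 nM and another limit is the likeliest report.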

Compound 4, half-maximal effective concentration: > 100000 nM
Compound 4 was reported as a limit (the forecaster's own chance of this, stated with the estimate: 70%); the middle value sits exactly at the limit.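

No step can be read from compound 1 to compound 4, because both results are limits and not numbers: the limit of > 100000 nM in this assay, at which 4 of the 4 values shown sit.

The compounds shown leave open whether acetamido in place of nitro changes the result in this assay at all.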